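Cytotoxicity on Vero 76 Cells: From Compound 2 to 4

A few compounds are considered here, and "the series" means these few. Any claim that something is new, unique, unknown or untested is made for them only; others in the source may bear on it.

Three measured compounds share one core. In an ADME assay on Vero 76 cells (Chlorocebus sabaeus) for cytotoxicity, read by crystal violet staining, with a stated time of 96 h (a higher number here means that more compound is tolerated, a lower number that less compound is tolerated), compound 1 `COc1cccc(NC(=S)Nc2cccc(C(F)(F)F)c2)c1` gives 20000 nM and compound 3 `CCOC(=O)c1ccc(NC(=S)Nc2cccc(C(F)(F)F)c2)cc1` gives 71000 nM. Compound 2 `C=C(C)CNC(=S)Nc1cccc(C(F)(F)F)c1` reaches only a limit of this assay, recorded as > 100000 nM. This is the limit of > 100000 nM in this assay, at which 1 of the 3 values shown sits, so where compound 2 truly stands is not fixed by a number. Compound 4 `CSCCCNC(=S)Nc1cccc(C(F)(F)F)c1` has not yet been measured in this assay; it differs from compound 2 by 2-(methylsulfanyl)ethyl in place of 1-methylethenyl on a saturated chain carbon bound to an amide-type nitrogen. The step from compound 2 to compound 4 is expected to be a number no higher from compound 2 to compound 4 (the limit leaves the size open), which amounts to none beyond the scatter. Compound 4 is therefore estimated at 100000 nM, with a range from 40000 nM to 200000 nM.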

Compound 4, half-maximal cytotoxic concentration: > 100000 nM
Compound 4: only a limit was reported; the forecaster's own chance of this, stated with the estimate: 60%; the middle value lies on the limit itself.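

In this assay compound 4 gives > 100000 nM, a limit and not a number. Compound 2 gives > 100000 nM, also a limit, so no step can be read from compound 2 to compound 4: the limit of > 100000 nM in this assay, at which 2 of the 4 values shown sit.

The compounds shown leave open whether 2-(methylsulfanyl)ethyl in place of 1-methylethenyl changes tolerance at all.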